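Swapping Fluoro for Methoxy on an Aromatic Carbon

This account rests on a few compounds, and the source may have more. Where it says the series, first, only, none or still open, it means among the compounds named here.

Of the compounds shown here, two have so far been measured in a functional assay on MCF7 cells (Homo sapiens) for cytotoxicity, read by MTT assay, with a stated time of 2 days, tested at 10 uM; on this read-out higher numbers stand for a weaker effect at the one concentration tested and lower numbers for a stronger effect. Compound 1 `CC(=O)c1cc(/C=C/c2ccc(F)cc2)cc2cc(-c3ccccc3)[nH]c12` gives 46.5%. Compound 2 `CC(=O)c1cc(/C=C/c2ccc(F)cc2)cc2cc(-c3ccc(F)cc3)[nH]c12` carries a fluoro where compound 1 carries a hydrogen; in this assay compound 2 gives 67.4%. Among the measured compounds shown here, the one step recorded between them, a number 20.9 percentage points higher from compound 1 to compound 2 (beyond the scatter), shows that the fluoro weakened the effect at the concentration tested. On the numbers shown, compound 2 stands as the higher of the two, that is, the weaker of the two.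

Compound 3 `COc1ccc(-c2cc3cc(/C=C/c4ccc(F)cc4)cc(C(C)=O)c3[nH]2)cc1` is not yet measured. It differs from compound 2 in one place: methoxy in place of fluoro on an aromatic carbon. For the measured compounds named here, no measured step exchanges fluoro for methoxy, so the only guide is that an earlier change on an aromatic carbon, from hydrogen to fluoro, moved the read-out by a modest amount. A further change of this kind is therefore expected to move the read-out by at most a similar amount, and its direction cannot be told from the data at hand. The estimate for compound 3 is 62%, within a range from 40% to 85%. The step expected is a number 5.4 percentage points lower from compound 2 to compound 3 (within the scatter).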

Compound 3, a percentage reported as activity, at one concentration (the size of the read-out at that concentration, not a potency): 76.5%
Compound 3: middle estimate off by 14.5 percentage points, on the low side; low and high end bracket the measured number.
By their numbers in this assay, from the lowest: compound 1; then compounds 2 and 3 (each within the scatter of the next).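

In this assay the exchange of fluoro for methoxy on this aromatic carbon, para to a large group, gives a number 9.1 percentage points higher from compound 2 to compound 3 (within the scatter) and so leaves compound 2 and compound 3 indistinguishable on this read-out. Set against the hydrogen of compound 1, the methoxy gives a number 30 percentage points higher from compound 1 to compound 3 (beyond the scatter) and joins the earlier fluoro result, a number 20.9 percentage points higher from compound 1 to compound 2 (beyond the scatter) as a second case of a weaker effect at the concentration tested. Among these three compounds, then, the clear difference lies between having hydrogen at this position and having either of the two groups, while the choice between fluoro and methoxy does not register beyond the scatter, and nothing on hand says why either group behaves as it does.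

Going by these compounds, it remains open whether any group on this carbon can match or better the hydrogen of compound 1, for instance an amine, a carboxylic acid or a longer chain such as ethoxy. Also open, on these data alone, is whether moving the fluoro or the methoxy to another place on the same ring would give the same picture, and how these single-concentration readings would translate into potency.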